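Swapping the aryl group on the aromatic nitrogen of compound 3

The source may report more compounds than this note shows. Statements on the series, on what has been measured and on what is new or still open speak of the compounds shown alone.

Measured in a functional assay on MDA-MB-231 cells (Homo sapiens) for inhibition, read by MTT assay, with a stated time of 72 h; a higher number here means a weaker inhibitor, a lower number a stronger inhibitor:
- compound 1 `Cc1ccc(C(C)C)c(OCc2cn(-c3cccc(Cl)c3)nn2)c1`: 45200 nM
- compound 2 `Cc1ccc(C(C)C)c(OCc2cn(-c3ccc(F)cc3)nn2)c1`: 32600 nM
- compound 3 `COc1ccc(-n2cc(COc3cc(C)ccc3C(C)C)nn2)cc1`: 45300 nM

The three compounds share one core and differ only in the aryl group on an aromatic nitrogen. Compound 3 stands level with the other two within the scatter, as its two steps show: a 1.0-fold higher number from compound 1 to compound 3 (0.00 log units; within the scatter), and a 1.4-fold higher number from compound 2 to compound 3 (0.14 log units; within the scatter).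

The next compound, compound 4 `Cc1cccc(-n2cc(COc3cc(C)ccc3C(C)C)nn2)c1`, carries 3-methylphenyl in place of 4-methoxyphenyl on an aromatic nitrogen. The rest of the structure stays as it is in compound 3.

Among the measured compounds shown here, all the measured steps bear on this change, since each exchanges one aryl group for another at this same place. The third of them is a 1.4-fold lower number from compound 1 to compound 2 (0.14 log units; within the scatter). None of the three steps leaves the scatter, whether the group is 3-chlorophenyl, 4-fluorophenyl or 4-methoxyphenyl. For the measured compounds named here, no compound with 3-methylphenyl has been measured, so this reading is carried over from the other groups, and no shift beyond the scatter is expected in this assay.

The expected change is a 1.1-fold lower number from compound 3 to compound 4 (0.05 log units; within the scatter). Compound 4 is estimated at 40000 nM, with an expected range from 23000 nM to 70000 nM.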

Compound 4, half-maximal inhibitory concentration: 31300 nM
The estimate for compound 4 lay 1.3-fold (0.11 log units) above the measured number; low and high end bracket the measured number.
By their numbers in this assay, from the lowest: compounds 4, 2, 1 and 3 (each within the scatter of the next).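

In this assay, 3-methylphenyl stays level with each of the three other aryl groups on the aromatic nitrogen: a 1.4-fold lower number from compound 3 to compound 4 (0.16 log units; within the scatter), a 1.0-fold lower number from compound 2 to compound 4 (0.02 log units; within the scatter) and a 1.4-fold lower number from compound 1 to compound 4 (0.16 log units; within the scatter). The flat reading at this position therefore now extends to a group without the hydrogen-bond acceptor counted in 4-methoxyphenyl, and the exchange of methyl for chloro on an aromatic carbon also stays within the scatter. Nothing available explains why these numbers remain level.

On these data alone, all four compounds carry a substituted phenyl group at this position, so it remains open whether an amine or a carboxylic acid on that group would give a step beyond the scatter in this assay. The rest of the shared core is the same throughout, so these compounds also cannot show whether a change elsewhere, such as a longer chain on the core, would move the number more than any exchange of the aryl group has done.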